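This account rests on a few compounds, and the source may have more. Where it says the series, first, only, none or still open, it means among the compounds named here.

Compound 1 `O=C1/C(=C/c2ccc(F)cc2)CCC/C1=C\c1cccc([N+](=O)[O-])c1` gives 36000 nM in an ADME assay on HPLF cells (Homo sapiens) for cytotoxicity, with a stated time of 24 h; on this read-out lower numbers stand for higher toxicity in this test and higher numbers for lower toxicity in this test. Compound 2 `O=C1/C(=C/c2ccc(Cl)cc2)CCC/C1=C\c1cccc([N+](=O)[O-])c1` gives 38000 nM. Compound 3 `O=C1/C(=C/c2ccc(F)cc2)CCC/C1=C\c1ccc([N+](=O)[O-])cc1` reached only the limit of the assay, > 400000 nM.

Compound 1 and compound 2 share a core and differ by chloro in place of fluoro on an aromatic carbon; this gave a 1.1-fold higher number from compound 1 to compound 2 (0.02 log units; within the scatter). Compound 3 carries the same atoms as compound 1 joined differently; the difference between the two cores is not broken down here. Compound 4 `O=C1/C(=C/c2ccc(Cl)cc2)CCC/C1=C\c1ccc([N+](=O)[O-])cc1` stands to compound 3 as compound 2 stands to compound 1, the change being (chloro in place of fluoro on an aromatic carbon), the same change at the same place. Since compound 3 sits at the limit of > 400000 nM in this assay, at which 1 of the 3 values shown sits, and the earlier step was within the scatter, compound 4 is expected to sit near that limit too, with a step that the limit leaves unreadable from compound 3 to compound 4 estimated. Compound 4 is therefore estimated at 500000 nM, between 150000 nM and 2000000 nM.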

Compound 4, half-maximal cytotoxic concentration: 332000 nM
The estimate for compound 4 lay 1.5-fold (0.18 log units) above the measured number, and the stated range covers the measured number.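

In this assay the change from 4-fluorophenyl to 4-chlorophenyl, carried over to the core of compound 3, gives an at least 1.2-fold lower number from compound 3 to compound 4 (0.08 log units; that floor lies within the scatter), and set beside the earlier step it reads: the same change on two cores in this assay, a 1.1-fold higher number (0.02 log units; within the scatter) from compound 1 to compound 2 and an at least 1.2-fold lower number (0.08 log units; that floor lies within the scatter) from compound 3 to compound 4; the limit leaves it open whether they differ. Compound 3 stands at a limit of the assay, > 400000 nM, and not at a number. From the compounds shown here alone, the result fits a change that carries over between the two cores with little effect, but it does not establish this, since the true size of the step on the core of compound 3 stays unknown.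

The compounds shown leave open how a bromo or a methyl group would read at the same place. They also leave open how an amine in place of the nitro group would read on either core.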